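A few compounds are considered here, and "the series" means these few. Any claim that something is new, unique, unknown or untested is made for them only; others in the source may bear on it.

Compound 1 `Cc1cc(Cl)ccc1OCc1nnc(-c2ccccc2F)o1`: in an ADME assay on cells for inhibition of anoctamin-2 (Homo sapiens), read by fluorescence, with a stated time of 20 min (on this read-out lower numbers stand for stronger inhibition and higher numbers for weaker inhibition), compound 1 gives > 100000 nM, which is a limit of the assay and not a number.
Compound 2 `Cc1cc(Cl)ccc1OCc1nnc(-c2ccccc2C(F)(F)F)o1`: in this assay compound 2 gives > 100000 nM, again a limit and not a number.
Compound 3 `COc1cccc(/C=N/NC(=O)COc2ccc(Cl)cc2C)c1`: in this assay compound 3 is reported as "not active" (no number reported), with no number attached.

Compound 2 therefore stands only at a limit. Among the measured compounds shown here, of the three values shown, two sit at the same limit of > 100000 nM in this assay, at which 2 of the 3 values shown sit, and the third carries no number, so no compound in this set can be placed above or below another. For the measured compounds named here, the single measured step, a step that the two limits leave unreadable from compound 1 to compound 2, runs between two limits and its size cannot be read.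

Compound 4 `COc1ccccc1-c1nnc(COc2ccc(Cl)cc2C)o1` is the compound not yet measured. It differs from compound 2 by methoxy in place of trifluoromethyl on an aromatic carbon. The only step that bears on this change is a step that the two limits leave unreadable from compound 1 to compound 2, and since it is unreadable, the data give no direction and no size for the move to compound 4; a step beyond the scatter in this assay cannot be predicted from what is shown.

Compound 4 is expected to give about 100000 nM in this assay, with a range from 30000 nM to 300000 nM. The step from compound 2 to compound 4 is accordingly expected to be a number no higher from compound 2 to compound 4 (the limit leaves the size open).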

Compound 4, half-maximal inhibitory concentration: 12400 nM
Compound 4: middle estimate off by 8.1-fold (0.91 log units), on the high side; measured number outside the range, below it.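

In this assay, this position proves able to move the read-out on the shared core: methoxy in place of trifluoromethyl gives an at least 8.0-fold lower number from compound 2 to compound 4 (0.90 log units; beyond the scatter), and methoxy in place of fluoro gives an at least 8.0-fold lower number from compound 1 to compound 4 (0.90 log units; beyond the scatter). Among the compounds shown here, both sizes are only lower bounds, so the true distance from either neighbour could be larger, but methoxy is the first of these three groups on this aromatic carbon to yield a number rather than a limit. Compound 1 and compound 2 remain at a limit of the assay and not a number, which is all that can be said of them: the limit of > 100000 nM in this assay, at which 2 of the 4 values shown sit.

The step between those two compounds cannot be read, so fluoro and trifluoromethyl cannot be ranked against each other, and nothing shown separates the hydrogen-bond acceptor that methoxy brings from any other difference between the groups. As far as these compounds go, how a hydroxyl, an amine or a longer chain such as ethoxy would read at this position remains open, as does the effect of methoxy on any other carbon of this ring.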